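The source may report more compounds than this note shows. Statements on the series, on what has been measured and on what is new or still open speak of the compounds shown alone.

Compound 1 `CC(C(=O)NCc1ccc(C(F)(F)F)nc1NCc1ccc(Cl)cc1)c1ccc(NS(C)(=O)=O)c(F)c1`: 65.7 nM
Compound 2 `C[C@H](C(=O)NCc1ccc(C(F)(F)F)nc1N1CC[C@@H](N(C)C)C1)c1ccc(NS(C)(=O)=O)c(F)c1`: 101 nM
Compound 3 `CC(C(=O)NCc1ccc(C(F)(F)F)nc1N1CCC(Cc2cc(F)cc(F)c2)CC1)c1ccc(NS(C)(=O)=O)c(F)c1`: 0.4 nM

Of these three, compound 3 has the lowest number in a functional assay on CHO-K1 cells for antagonist activity at transient receptor potential cation channel subfamily V member 1 (Homo sapiens), read by FLIPR (a higher number here means a weaker inhibitor, a lower number a stronger inhibitor), and its gap to compound 1 and to compound 2 lies well beyond the scatter, so it is the strongest inhibitor measured here. Compound 4 `CC(C(=O)NCc1ccc(C(F)(F)F)nc1N1CCC(OC(=O)C(C)(C)C)CC1)c1ccc(NS(C)(=O)=O)c(F)c1` has not yet been measured in this assay. It differs from compound 3 in one place: ((tert-butyl)carbonyl)oxy in place of 3,5-difluorobenzyl on a saturated ring carbon. Among the measured compounds shown here, no measured pair shows this particular change, so the expectation rests only on the three values above. Since compound 1 and compound 2, which carry smaller or quite different groups at the shared position, give far higher numbers than compound 3, the step of a 38-fold higher number from compound 3 to compound 4 (1.57 log units; beyond the scatter) is expected to go upward, toward weaker inhibition, beyond the scatter. Compound 4 is therefore estimated at 15 nM, with a likely range from 2 nM to 150 nM.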

Compound 4, inhibition constant: 2 nM
Compound 4: the middle estimate sits 7.5-fold (0.88 log units) above what was measured, within the range that was stated.
By their numbers in this assay, from the lowest: compound 3; then compound 4; then compounds 1 and 2 (each within the scatter of the next).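

In this assay, putting ((tert-butyl)carbonyl)oxy in place of 3,5-difluorobenzyl on the saturated ring carbon is a modest change (a 5.0-fold higher number from compound 3 to compound 4 (0.70 log units; beyond the scatter)), though beyond the scatter. Thus a very low number at this position does not depend on an aromatic ring in this group, since the entering group has no ring and carries two hydrogen-bond acceptors. Nothing measured here gives a reason for the step. Still open, on these data alone, is how a plain hydroxyl, an acetyloxy group or a primary amine would behave on this ring carbon.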